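This account rests on a few compounds, and the source may have more. Where it says the series, first, only, none or still open, it means among the compounds named here.

Compound 1 `Cc1ccc(N(C(=O)c2ccc(F)cc2F)C(=S)OCCN2C(=O)c3ccccc3C2=O)cc1`: 20000 nM
Compound 2 `Cc1ccc(N(C(=O)c2cccc(Cl)c2Cl)C(=S)OCCN2C(=O)c3ccccc3C2=O)cc1`: 35000 nM

In an ADME assay on MT4 cells (Homo sapiens) for cytotoxicity, read by MTT assay (a lower number here means that less compound is tolerated, a higher number that more compound is tolerated), compound 2 gives 35000 nM, which lies within the scatter of compound 1 at 20000 nM. Compound 3 `Cc1ccc(N(C(=O)c2ccc([N+](=O)[O-])cc2Cl)C(=S)OCCN2C(=O)c3ccccc3C2=O)cc1` keeps the shared core and differs from compound 2 on a carbonyl carbon: 2-chloro-4-nitrophenyl in place of 2,3-dichlorophenyl on a carbonyl carbon. Going by the values given here, the only measured step, a 1.8-fold higher number from compound 1 to compound 2 (0.24 log units; within the scatter), changed the group at that same place, so no change beyond the scatter is expected, although no measured compound carries the 2-chloro-4-nitrophenyl group. The expected step is a 1.2-fold lower number from compound 2 to compound 3 (0.07 log units; within the scatter). For compound 3 the estimate is 30000 nM, with an expected range of 12000 nM to 70000 nM.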

Compound 3, half-maximal cytotoxic concentration: 17000 nM
For compound 3 the middle estimate is 1.8-fold (0.25 log units) above the measured one; measured number inside the range.
By their numbers in this assay, from the lowest: compounds 3, 1 and 2 (each within the scatter of the next, the first and the last beyond it).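

In (this assay), this place on a carbonyl carbon now shows a step beyond the scatter, though a modest one (a 2.1-fold lower number from compound 2 to compound 3 (0.31 log units; beyond the scatter)). The same 2-chloro-4-nitrophenyl group stays within the scatter when it replaces 2,4-difluorophenyl (a 1.2-fold lower number from compound 1 to compound 3 (0.07 log units; within the scatter)), so the reading at this place differs with the group replaced. Nothing available accounts for this difference. Still open, from the compounds shown here alone, is whether a phenyl ring carrying an amine or a carboxylic acid in place of the nitro group would give a clearer separation from compound 2.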